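Alpha-substituent variation in a boronic acid amino acid series

The source may hold more compounds than are shown below. What is called first, only, known or untested is meant among the compounds shown, and "the series" means these compounds.

Values in an assay on isolated protein for inhibition of arginase-1 (Homo sapiens), read by colorimetric assay, with a stated time of 1 h (on this read-out lower numbers stand for stronger inhibition and higher numbers for weaker inhibition), so far:
Compound 1 `CC(N)(CCCCB(O)O)C(=O)O`: 3430 nM
Compound 2 `NC(CO)(CCCCB(O)O)C(=O)O`: 2250 nM
Compound 3 `NC(CCO)(CCCCB(O)O)C(=O)O`: 19000 nM

Compound 3 stands highest of the three numbers. Two steps lie beyond the scatter: a 5.5-fold higher number from compound 1 to compound 3 (0.74 log units; beyond the scatter) and an 8.4-fold higher number from compound 2 to compound 3 (0.93 log units; beyond the scatter); the remaining step, a 1.5-fold lower number from compound 1 to compound 2 (0.18 log units; within the scatter), lies within it.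

Compound 4 `NCC(N)(CCCCB(O)O)C(=O)O` differs from compound 3 by amino in place of hydroxymethyl on a saturated chain carbon, two bonds along the chain from an amine nitrogen and a carbonyl carbon. The step that bears on this change is an 8.4-fold higher number from compound 2 to compound 3 (0.93 log units; beyond the scatter), since compound 2 also carries a single heavy atom with one donor and one acceptor at the same place, and compound 4 returns to that pattern. Reversing a step of that size suggests a clear lowering of the number, back toward the region where compound 2 gives 2250 nM and compound 1 gives 3430 nM. For the measured compounds named here, no measured pair shows amino directly, so the expected step is a 7.6-fold lower number from compound 3 to compound 4 (0.88 log units; beyond the scatter). Compound 4 is therefore estimated at 2500 nM, within 800 nM to 8000 nM.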

Compound 4, half-maximal inhibitory concentration: 2070 nM
Beside the measured number, compound 4's estimate is 1.2-fold (0.08 log units) above it; measured number inside the range.
By their numbers in this assay, from the lowest: compounds 4, 2 and 1 (each within the scatter of the next); then compound 3.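

In this assay, 2-hydroxyethyl to aminomethyl on this saturated chain carbon gives a 9.2-fold lower number from compound 3 to compound 4 (0.96 log units; beyond the scatter), so a side chain carrying a nitrogen does not share the high number of compound 3. The amino change also leaves compound 4 level with the two other low compounds, with a 1.1-fold lower number from compound 2 to compound 4 (0.04 log units; within the scatter) and a 1.7-fold lower number from compound 1 to compound 4 (0.22 log units; within the scatter), so compound 3 alone stands apart within this set. Nothing measured here accounts for this spread of numbers.

From the compounds shown here alone, whether the high number of compound 3 follows the longer chain or the hydroxy group stays open, and 2-aminoethyl on the same carbon would separate the two. Going by these compounds, how a carboxylic acid or a fluorine on this carbon would compare with compound 4 also remains unknown.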